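A Smaller Ester in Place of the Anilide

A few compounds are considered here, and "the series" means these few. Any claim that something is new, unique, unknown or untested is made for them only; others in the source may bear on it.

Compound 2 `CC1=C(C(=O)Nc2ccccc2Cl)C(c2ccc(Br)cc2)NC(=O)N1` has been tested in an ADME assay on Vero cells (Chlorocebus sabaeus) for cytotoxicity, read by XTT assay, with a stated time of 72 h; a lower number here means that less compound is tolerated, a higher number that more compound is tolerated. Compound 2 gives > 100000 nM, which is a limit of the assay rather than a number, as the limit of > 100000 nM in this assay, at which 1 of the 3 values shown sits, records. Two further entries carry no number: compound 1 `CC1=C(C(=O)Nc2ccccc2Cl)C(c2ccccc2Cl)NC(=O)N1` is reported as "non-toxic" (no number reported), and compound 3 `CC1=C(C(=O)Nc2ccccc2Cl)C(c2ccc([N+](=O)[O-])cc2)NC(=O)N1` as "non-toxic" (no number reported). Compound 4 `COC(=O)C1=C(C)NC(=O)NC1c1ccc(Br)cc1` is not yet measured. It differs from compound 2 by a single change (methoxy in place of (2-chlorophenyl)amino on a carbonyl carbon), methoxy in place of (2-chlorophenyl)amino on a carbonyl carbon. For the measured compounds named here, no measured step of this kind exists among the three compounds. Since every result so far sits at a limit or without a number, the step expected a step that the limit leaves unreadable from compound 2 to compound 4 is none beyond the scatter. Compound 4 is expected to give 200000 nM, with a range from 50000 nM to 1000000 nM, most likely reported only as a limit again.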

Compound 4, half-maximal cytotoxic concentration: 100000 nM
Estimate against measurement, compound 4: 2.0-fold (0.30 log units) above, and the stated range covers the measured number.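

For the compounds shown here, compound 4 brings the first plain number at this position in this assay: compound 4 gives 100000 nM. Methoxy in place of (2-chlorophenyl)amino on this carbonyl carbon gives a number no higher from compound 2 to compound 4 (the limit leaves the size open), so the aromatic ring of the leaving group is not required for a value of this order. How large the step really is stays unreadable, because the result for compound 2 is only a limit: the limit of > 100000 nM in this assay, at which 1 of the 4 values shown sits.

Going by these compounds, whether a carboxylic acid or a longer ester chain on this carbonyl carbon would be tolerated as well stays open. So does whether methoxy would give a similar result on the cores of compound 1 and compound 3.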